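Aryl carbamates on a shared core: from chloro to trifluoromethyl

The source may hold more compounds than are shown below. What is called first, only, known or untested is meant among the compounds shown, and "the series" means these compounds.

Measured so far:
compound 1 `CC(C)=CCC1Cc2c(OC(=O)Nc3ccc(F)c(F)c3)cc(=O)n(CCCO)c2CC1(C)C` gives 76.7%
compound 2 `CC(C)=CCC1Cc2c(OC(=O)Nc3ccc(Cl)cc3)cc(=O)n(CCCO)c2CC1(C)C` gives 49.8%

For the measured compounds named here, in a functional assay on PANC-1 cells (Homo sapiens) for inhibition, read by MTT assay, with a stated time of 24 h, tested at 10 uM (a lower number here means less inhibition, a higher number more inhibition at the concentration tested (going by the name of the read-out)), compound 2 stands lowest of the two numbers, with compound 1 as its nearest neighbour, the one measured step being a number 26.9 percentage points lower from compound 1 to compound 2 (beyond the scatter). Compound 3 `CC(C)=CCC1Cc2c(OC(=O)Nc3cccc(C(F)(F)F)c3)cc(=O)n(CCCO)c2CC1(C)C` differs from compound 2 by 3-(trifluoromethyl)phenyl in place of 4-chlorophenyl on an amide-type nitrogen. Going by the values given here, no measured step shares this exact exchange; the single step only shows that changing the aryl group moves the read-out modestly. Compound 3 is therefore expected to sit between the two measured values, estimated at 60% within 35% to 85%, an expected step of a number 10.2 percentage points higher from compound 2 to compound 3 (beyond the scatter).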

Compound 3, a percentage reported as inhibition, at one concentration (the size of the read-out at that concentration, not a potency): 54.3%
The estimate for compound 3 lay 5.7 percentage points above the measured number, within the range that was stated.
By their numbers in this assay, from the lowest: compounds 2 and 3 (each within the scatter of the next); then compound 1.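

In this assay, 3-(trifluoromethyl)phenyl in place of 4-chlorophenyl on the amide-type nitrogen gives a number 4.5 percentage points higher from compound 2 to compound 3 (within the scatter) and so does not separate these two aryl groups. The change from 3,4-difluorophenyl gives a number 22.4 percentage points lower from compound 1 to compound 3 (beyond the scatter) and so leaves compound 1 apart from both compound 2 and compound 3. No measurement shown accounts for this separation. On these data alone, whether a plain phenyl group, or an aryl group bearing a methoxy or a nitrile, would stand with compound 1 or with the other two remains open.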